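The compounds below may be only part of what the source reports. "The series", "measured", "known", "first", "only" and "open" are said of these compounds alone.

Measured so far in a functional assay on BaF3 cells (Mus musculus) for inhibition, read by CCK-8 assay, with a stated time of 72 h; on this read-out higher numbers stand for weaker inhibition of growth and lower numbers for stronger inhibition of growth:

- compound 1, `Cc1ccc(NC(=O)Nc2ccc(Oc3cc(NCc4ccccc4)ncn3)cc2)cc1C(F)(F)F`, gives 3010 nM
- compound 2, `COc1ccc(CNc2cc(Oc3ccc(NC(=O)Nc4ccc(C)c(C(F)(F)F)c4)cc3)ncn2)cc1`, gives 1000 nM
- compound 3, `C=CC(=O)Nc1cc(Oc2ccc(NC(=O)Nc3ccc(C)c(C(F)(F)F)c3)cc2)ncn1`, gives 1940 nM

Compound 3 sits between the other two on these numbers, but both gaps are within the scatter: a 1.6-fold lower number from compound 1 to compound 3 (0.19 log units; within the scatter) and a 1.9-fold higher number from compound 2 to compound 3 (0.29 log units; within the scatter). Going by the values given here, the only step beyond the scatter is a 3.0-fold lower number from compound 1 to compound 2 (0.48 log units; beyond the scatter), which does not touch the nitrogen varied here.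

Compound 4, `CNc1cc(Oc2ccc(NC(=O)Nc3ccc(C)c(C(F)(F)F)c3)cc2)ncn1`, differs from compound 3 as follows: methyl in place of vinylcarbonyl on a nitrogen on an aromatic ring.

Among the compounds with values here, the steps that bear on this are the two that change the group on the same nitrogen, from compound 1 and from compound 2 to compound 3; both stayed within the scatter, so three different groups on that nitrogen gave numbers close to each other in this assay. Nothing measured tells how a methyl at that position behaves, so no step beyond the scatter is expected in this assay for compound 4, in either direction; the estimate leans toward a slightly higher number because a 1.9-fold higher number from compound 2 to compound 3 (0.29 log units; within the scatter) already moved that way.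

Compound 4 is expected to give about 2500 nM, within 1000 nM to 6500 nM, a step of a 1.3-fold higher number from compound 3 to compound 4 (0.11 log units; within the scatter).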

Compound 4, concentration for 50% growth inhibition: > 10000 nM
Compound 4: no number, only a limit (the forecaster's own chance of this, stated with the estimate: 5%); at least 4.0-fold (0.60 log units) between middle value and limit.
By their numbers in this assay, from the lowest: compounds 2, 3 and 1 (each within the scatter of the next, the first and the last beyond it). At a limit, above all of these: compound 4.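

In this assay compound 4 stands at a limit, not at a number: the limit of > 10000 nM in this assay, at which 1 of the 4 values shown sits.

The group on this nitrogen does matter, since the steps read an at least 5.1-fold higher number from compound 3 to compound 4 (0.71 log units; beyond the scatter), an at least 10-fold higher number from compound 2 to compound 4 (1.00 log units; beyond the scatter) and an at least 3.3-fold higher number from compound 1 to compound 4 (0.52 log units; beyond the scatter), whereas a 1.6-fold lower number from compound 1 to compound 3 (0.19 log units; within the scatter) and a 1.9-fold higher number from compound 2 to compound 3 (0.29 log units; within the scatter) gave no such separation. Of the four groups shown, benzyl, 4-methoxybenzyl and vinylcarbonyl all give numbers in this assay, and only methyl gives a limit, so the position tolerates quite different groups but not every group.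

As far as these compounds go, it stays open whether an acetyl, which keeps the carbonyl without the vinyl double bond, would behave like vinylcarbonyl. An unsubstituted amine or a longer alkyl chain on the same nitrogen would show whether the limit belongs to methyl alone or extends to small groups generally.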